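The source may hold more compounds than are shown below. What is called first, only, known or untested is meant among the compounds shown, and "the series" means these compounds.

In an ADME assay on CHO cells (Cricetulus griseus) for cytotoxicity, read by MTT assay (a lower number here means a stronger inhibitor, a higher number a weaker inhibitor), compound 1 `O=C(CCc1ccc(CN2CCCCC2)c(O)c1)c1cccs1` gives 168000 nM, compound 2 `Oc1cc(CCCc2ccc(F)cc2)ccc1CN1CCCCC1` gives 163000 nM, and compound 3 `CCc1ccc(CCCc2ccc(CN3CCCCC3)c(O)c2)cc1` gives 25200 nM, the lowest of the three numbers. Compound 4 `Oc1cc(CCCc2ccccc2)ccc1CN1CCCCC1` differs from compound 3 by one change: hydrogen in place of ethyl on an aromatic carbon, para to a large group. The step of a 1.0-fold lower number from compound 1 to compound 2 (0.01 log units; within the scatter) lies within the scatter and offers little guidance. The step that bears on the change is a 6.5-fold lower number from compound 2 to compound 3 (0.81 log units; beyond the scatter), a modest one with ethyl in place of fluoro on an aromatic carbon, so a move of similar size in the opposite direction is expected. The estimated step is a 4.4-fold higher number from compound 3 to compound 4 (0.64 log units; beyond the scatter), towards a higher number. Compound 4 is expected at 110000 nM, with an estimated range from 45000 nM to 220000 nM.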

Compound 4, half-maximal inhibitory concentration: 162000 nM
For compound 4 the middle estimate is 1.5-fold (0.17 log units) below the measured one; the measured number falls inside the stated range.
By their numbers in this assay, from the lowest: compound 3; then compounds 4, 2 and 1 (each within the scatter of the next).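

In this assay hydrogen and fluoro on this aromatic carbon, para to a large group, cannot be told apart (the step is a 1.0-fold lower number from compound 2 to compound 4 (0.00 log units; within the scatter)), while ethyl stands alone among the three groups (the step is a 6.4-fold higher number from compound 3 to compound 4 (0.81 log units; beyond the scatter)). Benzyl in place of (thiophen-2-yl)carbonyl on the chain likewise leaves the number where it was (the step is a 1.0-fold lower number from compound 1 to compound 4 (0.02 log units; within the scatter)). Nothing available speaks to what lies behind the ethyl step. On these data alone, whether propyl, methoxy or an amine at this place would move the number as ethyl does stays open.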